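This account rests on a few compounds, and the source may have more. Where it says the series, first, only, none or still open, it means among the compounds named here.

Measured compounds, solubility in a physicochemical assay for solubility, read by spectrophotometry, measured as kinetic solubility, at pH 8, tested at 500 uM; a lower number here means a less soluble compound, a higher number a more soluble compound:
compound 1 `Cn1ccc2ccc(-c3cc(Nc4ccccc4S(=O)(=O)Nc4cncnc4)cc4nccnc34)cc21`, 254 ug/mL
compound 2 `CN1CCCC(NS(=O)(=O)c2ccccc2Nc2cc(-c3ccc4ccn(C)c4c3)c3nccnc3c2)C1`, 9 ug/mL
compound 3 `Cn1cc(NC(=O)c2ccncc2Nc2cc(-c3ccc4ccn(C)c4c3)c3nccnc3c2)cn1`, 2 ug/mL

Compound 3 stands lowest of the three in this assay; compound 2 gives 9 ug/mL and compound 1 gives 254 ug/mL, both above it by more than the scatter. Compound 4 `CC(=O)N1CC(CNC(=O)c2ccncc2Nc2cc(-c3ccc4ccn(C)c4c3)c3nccnc3c2)C1` is not yet measured. It differs from compound 3 in one place: (1-acetylazetidin-3-yl)methyl in place of 1-methyl-1H-pyrazol-4-yl on an amide-type nitrogen.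

Within the data shown here, only one step is measured, and it sits on a sulfonamide nitrogen rather than on an amide-type nitrogen: a 28-fold lower number from compound 1 to compound 2 (1.45 log units; beyond the scatter). That step swaps one ring for another, while the change to compound 4 replaces an aromatic ring by a four-membered non-aromatic ring carried on a methyl link, so it bears on the present case only loosely. Among the measured compounds shown here, no measured step separates an aromatic from a non-aromatic substituent on this amide position. The expectation for compound 4 is therefore an increase of modest size, a 3.0-fold higher number from compound 3 to compound 4 (0.48 log units; beyond the scatter), with a wide range. Compound 4 is estimated at 6 ug/mL, between 1.5 ug/mL and 30 ug/mL.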

Compound 4, solubility: 252 ug/mL
Estimate against measurement, compound 4: 42-fold (1.62 log units) below, outside the stated range (above it).
By their numbers in this assay, from the lowest: compound 3; then compound 2; then compounds 4 and 1 (each within the scatter of the next).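

On an amide-type nitrogen, the substituent has a large effect in this assay: (1-acetylazetidin-3-yl)methyl in place of 1-methyl-1H-pyrazol-4-yl gives a 130-fold higher number from compound 3 to compound 4 (2.10 log units; beyond the scatter). Among these compounds, the only earlier step, on a sulfonamide nitrogen, also put a non-aromatic ring in place of an aromatic one but ran the other way, with a 28-fold lower number from compound 1 to compound 2 (1.45 log units; beyond the scatter), so across these two positions such a swap has no single direction. Nothing measured here bears on why the step at the amide-type nitrogen is so large.

Still open, on these data alone, is which part of the entering group goes with the step: the acetyl, the azetidine ring or the methyl link. The free azetidine amine without the acetyl, or a plain alkyl chain on the same nitrogen, would begin to separate these parts.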